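Adding a Hydroxy Group: Three Measured Compounds, One Pending

This account rests on a few compounds, and the source may have more. Where it says the series, first, only, none or still open, it means among the compounds named here.

Compound 1, `O=c1c(Cc2coc3cccc(OCC4CCCCC4)c3c2=O)coc2ccccc12`, gives 4510 nM
Compound 2, `O=c1c(Cc2coc3cccc(OCC4CCCCC4)c3c2=O)coc2cc(O)ccc12`, gives 4250 nM
Compound 3, `O=c1c(Cc2coc3ccccc3c2=O)coc2ccccc12`, gives 7400 nM

All three values come from a functional assay on PC-3 cells (Homo sapiens) for antiproliferative activity, read by XTT assay; a higher number here means a weaker inhibitor, a lower number a stronger inhibitor. Compound 3 differs from compound 1 by hydrogen in place of cyclohexylmethoxy on an aromatic carbon, and that change gave a 1.6-fold higher number from compound 1 to compound 3 (0.22 log units; within the scatter). Compound 2 differs from compound 1 by hydroxy in place of hydrogen on an aromatic carbon, a change that gave a 1.1-fold lower number from compound 1 to compound 2 (0.03 log units; within the scatter). Compound 4, `O=c1c(Cc2coc3cccc(O)c3c2=O)coc2ccccc12`, is not yet measured; it differs from compound 3 by hydroxy in place of hydrogen on an aromatic carbon. Going by the values given here, this is the same kind of change as the one from compound 1 to compound 2, but not the same, since the place is not identical: in compound 2 the hydroxy sits meta to a fused ring and para to a fused ring, whereas in compound 4 it sits ortho to a fused ring and meta to a fused ring. Because the earlier step of a 1.1-fold lower number from compound 1 to compound 2 (0.03 log units; within the scatter) stayed within the scatter, a similarly small step is expected here, namely a 1.1-fold lower number from compound 3 to compound 4 (0.06 log units; within the scatter). Compound 4 is therefore estimated at 6500 nM, with a range from 2500 nM to 16000 nM.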

Compound 4, half-maximal inhibitory concentration: 5950 nM
The estimate for compound 4 lay 1.1-fold (0.04 log units) above the measured number, and the stated range covers the measured number.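

In this assay, hydroxy in place of hydrogen on an aromatic carbon gave a 1.2-fold lower number from compound 3 to compound 4 (0.09 log units; within the scatter), and the two cores carrying this change do not differ in their response: the same change on two cores in this assay, a 1.1-fold lower number (0.03 log units; within the scatter) from compound 1 to compound 2 and a 1.2-fold lower number (0.09 log units; within the scatter) from compound 3 to compound 4, 1.2-fold (0.07 log units) apart, within the scatter of two such steps. This shows that, on these two cores, the change left the number within the scatter both times, but it does not show that hydroxy makes a real contribution that carries over, since neither step can be told from repeated measurement and the hydroxy does not stand at the same place on the two cores. The other new step, hydrogen in place of cyclohexylmethyl on an oxygen on an aromatic ring, gave a 1.3-fold higher number from compound 1 to compound 4 (0.12 log units; within the scatter), which also stays within the scatter.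

From the compounds shown here alone, it remains open whether an amine or a carboxylic acid at the position ortho to a fused ring would move the number beyond the scatter. Going by these compounds, it is equally open whether a longer chain on that oxygen would do so.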